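Thiophene replaces the substituted phenyl of compound 3

The source may report more compounds than this note shows. Statements on the series, on what has been measured and on what is new or still open speak of the compounds shown alone.

Measured so far in a functional assay on U-251 cells (Homo sapiens) for antiproliferative activity, read by MTT assay, with a stated time of 48 h (a higher number here means a weaker inhibitor, a lower number a stronger inhibitor), with these results
Compound 1 `COc1cc(-c2cccc3nc(-c4ccccc4)oc23)cc(OC)c1OC` gives 3500 nM as a number
Compound 2 `COc1cc(-c2cccc3nc(-c4ccc(F)cc4)oc23)cc(OC)c1OC` gives > 25000 nM as a limit
Compound 3 `COc1cc(-c2nc3cccc(-c4cc(OC)c(OC)c(OC)c4)c3o2)ccc1O` gives 10300 nM as a number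

Of the two exact numbers, the higher belongs to compound 3, and the gap is a 2.9-fold higher number from compound 1 to compound 3 (0.47 log units; beyond the scatter) in this series. Compound 4 `COc1cc(-c2cccc3nc(-c4cccs4)oc23)cc(OC)c1OC` carries thiophen-2-yl in place of 4-hydroxy-3-methoxyphenyl on an aromatic carbon of the shared core.

Three measured steps change the group at this same place. Besides the step above, there are an at least 7.1-fold higher number from compound 1 to compound 2 (0.85 log units; beyond the scatter) for fluoro in place of hydrogen and an at least 2.4-fold lower number from compound 2 to compound 3 (0.38 log units; beyond the scatter) for the exchange of the two substituted phenyl groups. Thiophen-2-yl bears no substituent, so compound 4 is expected to lie nearer compound 1 at 3500 nM than to compound 3. A modest move toward a lower number is expected, namely a 2.3-fold lower number from compound 3 to compound 4 (0.36 log units; beyond the scatter) in this assay as the estimated step. The range stays wide, since these steps differ so much in size. For compound 4 the estimate is 4500 nM within an expected range of 1500 nM to 20000 nM in this series.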

Compound 4, half-maximal inhibitory concentration: 3000 nM
Compound 4: middle estimate off by 1.5-fold (0.18 log units), on the high side, within the range that was stated.
By their numbers in this assay, from the lowest: compounds 4 and 1 (each within the scatter of the next); then compound 3. At a limit, above all of these: compound 2.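

In this assay, thiophen-2-yl on this aromatic carbon, next to the ring nitrogen and next to the ring oxygen, matches phenyl within the scatter, as a 1.2-fold lower number from compound 1 to compound 4 (0.07 log units; within the scatter) shows, so a six-membered aromatic ring of carbon only is not needed here. Thiophen-2-yl also restores what 4-hydroxy-3-methoxyphenyl gave up, with a 3.4-fold lower number from compound 3 to compound 4 (0.54 log units; beyond the scatter). Compound 2 gives only a limit of the assay, so an at least 8.3-fold lower number from compound 2 to compound 4 (0.92 log units; beyond the scatter) is a bound and not a size: the limit of > 25000 nM in this assay, at which 1 of the 4 values shown sits.

The compounds shown leave open whether the hydroxy or the methoxy of 4-hydroxy-3-methoxyphenyl accounts for its step. They also leave open how furan-2-yl, pyridin-2-yl or a thiophene carrying an amine or a carboxylic acid would read at this position.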